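The source may report more compounds than this note shows. Statements on the series, on what has been measured and on what is new or still open speak of the compounds shown alone.

Measured so far:
- compound 1 `COc1ccccc1COc1ccccc1OCCNCCOc1c(OC)cccc1OC`, in an assay on CHO cells for displacement of a labelled ligand from Alpha-1D adrenergic receptor (Homo sapiens) (a lower number here means a stronger inhibitor, a higher number a weaker inhibitor), compound 1 gives 2 nM
- compound 2 `COc1cccc(COc2ccccc2OCCNCCOc2c(OC)cccc2OC)c1`, in this assay compound 2 gives 0.316 nM

Compound 2 holds the lowest number of the two; its nearest neighbour is compound 1, and the step of a 6.3-fold lower number from compound 1 to compound 2 (0.80 log units; beyond the scatter) lies beyond the scatter. Compound 3 `COc1ccc(COc2ccccc2OCCNCCOc2c(OC)cccc2OC)cc1` has not yet been measured. It differs from compound 2 in one place: 4-methoxyphenyl in place of 3-methoxyphenyl on a saturated chain carbon bound to an oxygen on an aromatic ring. Among the measured compounds shown here, the only measured step, from compound 1 to compound 2, concerns the same methoxyphenyl group but a different position of the methoxy, so it bears on compound 3 only loosely; it shows that moving that methoxy can shift the number noticeably, in that case downward. Nothing measured tells whether the 4-methoxyphenyl will do the same. The expected step of a 1.9-fold higher number from compound 2 to compound 3 (0.28 log units; within the scatter) is therefore small and uncertain in direction. Compound 3 is estimated at 0.6 nM in this assay, with a range from 0.15 nM to 3 nM.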

Compound 3, inhibition constant: 0.1 nM
Compound 3: the middle estimate sits 6.0-fold (0.78 log units) above what was measured, and the stated range ends above it.
By their numbers in this assay, from the lowest: compound 3; then compound 2; then compound 1.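

In this assay, moving the methoxy of this methoxyphenyl group a second time still matters: the step of a 3.2-fold lower number from compound 2 to compound 3 (0.50 log units; beyond the scatter) shows that 3-methoxyphenyl does not give the lowest number of the set. Across the three compounds, the number falls in order from 2-methoxyphenyl through 3-methoxyphenyl to 4-methoxyphenyl, and the whole span, a 20-fold lower number from compound 1 to compound 3 (1.30 log units; beyond the scatter), is large, so relocating a single methoxy, with no change in the atoms present, can shift the result considerably. Nothing available explains why the order runs this way.

Going by these compounds, it remains open whether the methoxy itself matters or whether other groups would serve equally well, such as plain phenyl, 4-chlorophenyl or 4-hydroxyphenyl. The compounds shown also leave open whether this same order would hold on any other receptor.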